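The compounds below may be only part of what the source reports. "The series", "measured", "known", "first", "only" and "open" are said of these compounds alone.

In a functional assay on the whole organism with Rattus norvegicus as the target, at a dose of 3 mg/kg by the oral route (a lower number here means a weaker effect, a higher number a stronger effect of the compound at the dose given), the three measured compounds gave these readings:

Compound 1, `COc1cc(C(=O)Nc2nn[nH]n2)nc(-c2ccccc2)c1`: 97%
Compound 2, `COc1ccc(-c2cc(OC)cc(C(=O)Nc3nn[nH]n3)n2)cc1`: 60%
Compound 3, `COc1cc(C(=O)Nc2nn[nH]n2)nc(-c2ccc(N(C)C)cc2)c1`: 100%

Compound 1 stands second highest of the three. Its nearest neighbour is compound 3, a number 3 percentage points higher from compound 1 to compound 3 (within the scatter), a gap within the scatter, so the two cannot be told apart on these numbers. Compound 2 lies furthest away, a number 37 percentage points lower from compound 1 to compound 2 (beyond the scatter), a step beyond the scatter. The remaining measured step, a number 40 percentage points higher from compound 2 to compound 3 (beyond the scatter), is also large. All three steps alter what sits on the phenyl group; none of them touches the methoxy on the shared core.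

Compound 4, `CCc1cc(C(=O)Nc2nn[nH]n2)nc(-c2ccccc2)c1`, differs from compound 1 at exactly that untested place: ethyl in place of methoxy on an aromatic carbon. Among the measured compounds shown here, no measured pair shows what exchanging this methoxy does, so the expectation rests on compound 1 alone. Because compound 1 already gives 97%, there is little room for a rise, and a modest drop would still sit within the scatter. The step is therefore expected to be a number 7 percentage points lower from compound 1 to compound 4 (within the scatter), not beyond the scatter. Compound 4 is estimated at 90%, with a likely range from 70% to 100%.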

Compound 4, a percentage reported as inhibition, in the whole organism at one dose (the size of the read-out at that dose, not a potency): 53%
Estimate against measurement, compound 4: 37 percentage points above; the measured number lies below the stated range.
By their numbers in this assay, from the lowest: compounds 4 and 2 (each within the scatter of the next); then compounds 1 and 3 (each within the scatter of the next).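

In this assay, the step from methoxy to ethyl is a number 44 percentage points lower from compound 1 to compound 4 (beyond the scatter), so this place on the shared core, opposite the ring nitrogen, is not a free spot where substituents can be exchanged at no cost. The exchange keeps the count of heavy atoms the same, yet it replaces the oxygen with carbon and removes the one hydrogen-bond acceptor of the methoxy, which shows that a group of the same heavy-atom count does not guarantee a similar reading at this dose. No measurement here bears on why the reading changes with this swap.

With a single replacement at this place, the compounds shown cannot separate the effect of losing the oxygen from that of adding the carbon, and a hydroxyl, an amino group or a longer ether such as ethoxy at the same position would help to tell these apart. Going by these compounds, it also remains open whether the same exchange would have a similar effect with the dimethylamino group on the phenyl ring of compound 3.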